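Replacing (methylsulfanyl)methyl with methylamino on a carbonyl carbon

The compounds below may be only part of what the source reports. "The series", "measured", "known", "first", "only" and "open" are said of these compounds alone.

Of the compounds shown here, three with a shared core have been measured in a functional assay (aorta) with Rattus norvegicus as the target; a lower number here means that less compound is needed, a higher number that more compound is needed for the effect. Compound 1 `COc1ccc(-c2nc(/N=C(\N)N(C)C)sc2-c2ccc(OC)cc2)cc1` gives 4.8 uM as its concentration for half-maximal effect, and compound 2 `COc1ccc(-c2nc(CNC(C)=O)sc2-c2ccc(OC)cc2)cc1` gives 8.1 uM on the same read-out. Compound 3 `COc1ccc(-c2nc(CNC(=O)CSC)sc2-c2ccc(OC)cc2)cc1` gives 6 uM and so stands within the scatter of both others. The data show a 1.3-fold higher number from compound 1 to compound 3 (0.10 log units; within the scatter) and a 1.4-fold lower number from compound 2 to compound 3 (0.13 log units; within the scatter) on either side of it, and the outer pair shows a 1.7-fold higher number from compound 1 to compound 2 (0.23 log units; within the scatter) as well.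

Compound 4 `CNC(=O)NCc1nc(-c2ccc(OC)cc2)c(-c2ccc(OC)cc2)s1` has not yet been measured. The difference from compound 3 is methylamino in place of (methylsulfanyl)methyl on a carbonyl carbon and amounts to methylamino in place of (methylsulfanyl)methyl on a carbonyl carbon. Among the compounds with values here, no measured step makes this exact replacement. The closest evidence is a 1.4-fold lower number from compound 2 to compound 3 (0.13 log units; within the scatter), a change on the same side of that carbonyl carbon. The larger replacements from compound 1 also stayed within the scatter, so the three values offer no sign of a sensitive position. On these data alone, no step beyond the scatter is therefore expected in this assay, and the direction remains open. The estimated step is a 1.2-fold higher number from compound 3 to compound 4 (0.07 log units; within the scatter) and is expected to be indistinguishable from no change. Compound 4 is estimated at 7 uM (expected range 3 uM to 16 uM).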

Compound 4, concentration for half-maximal effect: 15 uM
The estimate for compound 4 lay 2.1-fold (0.33 log units) below the measured number; low and high end bracket the measured number.
By their numbers in this assay, from the lowest: compounds 1, 3, 2 and 4 (each within the scatter of the next, the first and the last beyond it).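

In this assay, the group on this carbonyl carbon now proves able to shift the number beyond the scatter: methylamino in place of (methylsulfanyl)methyl gives a 2.5-fold higher number from compound 3 to compound 4 (0.40 log units; beyond the scatter), a modest step, whereas the earlier replacements had all stayed within it. Methylamino in place of methyl on the same carbonyl carbon gives a 1.9-fold higher number from compound 2 to compound 4 (0.27 log units; within the scatter), so compound 4 stands apart from compound 3 but not from compound 2. Within the data shown here, the larger replacement on the aromatic carbon gives a 3.1-fold higher number from compound 1 to compound 4 (0.49 log units; beyond the scatter), also modest, and is the first change at that carbon to pass the scatter. Nothing in the available evidence accounts for these steps.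

On these data alone, whether methylamino itself drives the higher number stays open, as compound 2 and compound 3 lie within the scatter of each other and only compound 3 is separated from compound 4. The compounds shown also leave open how a dimethylamino or a methoxy group on this carbonyl carbon would read in this assay, and so whether the step belongs to methylamino alone or extends to other groups there.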